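The source may hold more compounds than are shown below. What is called first, only, known or untested is meant among the compounds shown, and "the series" means these compounds.

Measured compounds:
compound 1, `CCOC(=O)C1=C(C)NC(COC(=O)c2ccccc2)=C(C(=O)OCC)C1c1cccc([N+](=O)[O-])c1`, 210 nM
compound 2, `COC(=O)C1=C(C)NC(C)=C(C(=O)OCC(F)(F)F)C1c1cccc([N+](=O)[O-])c1`, 16 nM

Both were tested in a functional assay on HEK293 cells for antagonist activity at Voltage-dependent L-type calcium channel subunit alpha-1C (Oryctolagus cuniculus), read by FLIPR; on this read-out higher numbers stand for weaker inhibition and lower numbers for stronger inhibition. Compound 1 gives 210 nM, and compound 2 gives 16 nM. Of the two numbers measured, compound 2 has the lowest, and its gap to compound 1 lies beyond the scatter of repeated measurements, so compound 2 is the stronger inhibitor of the pair. Compound 3, `COC(=O)C1=C(C)NC(C)=C(C(=O)OCCOc2ccccc2Cl)C1c1cccc([N+](=O)[O-])c1`, has not yet been measured. It differs from compound 2 in one place: (2-chlorophenoxy)methyl in place of trifluoromethyl on a saturated chain carbon bound to an oxygen next to a carbonyl group. Among the measured compounds shown here, no pair of measured compounds differs in exactly this way, so no earlier step shows how large an effect this change brings. For the measured compounds named here, with only two numbers in hand, compound 3 is expected to show a step of a 1.3-fold higher number from compound 2 to compound 3 (0.10 log units; within the scatter), which lies within the usual scatter. Compound 3 is therefore estimated at about 20 nM, with a likely range from 5 nM to 80 nM.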

Compound 3, half-maximal inhibitory concentration: 19 nM
The estimate for compound 3 lay 1.1-fold (0.02 log units) above the measured number; the measured number falls inside the stated range.
By their numbers in this assay, from the lowest: compounds 2 and 3 (each within the scatter of the next); then compound 1.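

In this assay, (2-chlorophenoxy)methyl in place of trifluoromethyl on a saturated chain carbon bound to an oxygen next to a carbonyl group brings a 1.2-fold higher number from compound 2 to compound 3 (0.07 log units; within the scatter), so the two compounds cannot be told apart on this read-out. Among the compounds shown here, this is the first step that can be read at this position. Here, a group of 9 heavy atoms with a six-membered aromatic ring and 1 hydrogen-bond acceptor takes the place of one with 4 heavy atoms and no ring, and the inhibition stays within the scatter. Nothing at hand explains why these two groups read alike.

From the compounds shown here alone, whether an amine, a carboxylic acid or a longer chain would read the same at this position stays open. So does the outcome for 2-phenoxyethyl, the same chain without the chlorine.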